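The source may hold more compounds than are shown below. What is called first, only, known or untested is meant among the compounds shown, and "the series" means these compounds.

Series values in an ADME assay on PC-12 cells (Rattus norvegicus) for cytotoxicity, read by MTT assay, with a stated time of 24 h; a lower number here means that less compound is tolerated, a higher number that more compound is tolerated:
- Compound 1 `COc1ccc(N2CCN(CC#CCOC(=O)c3sc4ncnc(N5CCCCC5)c4c3C)CC2)cc1`: 140 ug/mL
- Compound 2 `COc1cccc(N2CCN(CC#CCOC(=O)c3sc4ncnc(N5CCCCC5)c4c3C)CC2)c1`: 144 ug/mL

Compound 2, at 144 ug/mL, sits within the scatter of compound 1, at 140 ug/mL. Compound 3 `Cc1ccc(C#N)c(N2CCN(CC#CCOC(=O)c3sc4ncnc(N5CCCCC5)c4c3C)CC2)c1` has 2-cyano-5-methylphenyl in place of 3-methoxyphenyl on an amine nitrogen in a ring. Among the measured compounds shown here, the only measured step is a 1.0-fold higher number from compound 1 to compound 2 (0.01 log units; within the scatter), for 3-methoxyphenyl in place of 4-methoxyphenyl. For the measured compounds named here, no measured compound carries 2-cyano-5-methylphenyl, so this step is only weak guidance. The expected change is a 1.1-fold lower number from compound 2 to compound 3 (0.04 log units; within the scatter), with no step beyond the scatter anticipated. For compound 3, the estimate in this assay is 130 ug/mL, with an expected range of 65 ug/mL to 260 ug/mL.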

Compound 3, half-maximal cytotoxic concentration: 114 ug/mL
Beside the measured number, compound 3's estimate is 1.1-fold (0.06 log units) above it; the measured number falls inside the stated range.
By their numbers in this assay, from the lowest: compounds 3, 1 and 2 (each within the scatter of the next).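

In this assay, the earlier pair only moved a methoxy group on the phenyl ring, whereas 2-cyano-5-methylphenyl replaces that substitution outright, giving a 1.3-fold lower number from compound 2 to compound 3 (0.10 log units; within the scatter) and a 1.2-fold lower number from compound 1 to compound 3 (0.09 log units; within the scatter). Across compounds 1, 2 and 3, this change on the amine nitrogen in a ring therefore produces no step beyond the scatter, even with the methoxy oxygen gone and a nitrile present. No evidence on hand bears on these steps. As far as these compounds go, it remains open whether a carboxylic acid or a basic amine on this phenyl ring would move the number beyond the scatter. From the compounds shown here alone, the separate contributions of the cyano and methyl groups also remain open.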